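Swapping Chloro for Trifluoromethyl on the Urea Aryl Ring

The compounds below may be only part of what the source reports. "The series", "measured", "known", "first", "only" and "open" are said of these compounds alone.

Compound 1 `COc1cc(-c2nn(-c3cccc(NC(=O)Nc4ccc(Cl)c(Cl)c4)c3)cc2-c2ccncc2)ccc1Cl` and compound 2 `O=C(Nc1cccc(-n2cc(-c3ccncc3)c(-c3ccc(Cl)c(O)c3)n2)c1)Nc1ccc(Cl)c(Cl)c1` share one core and differ only in a hydrogen in place of methyl on an oxygen on an aromatic ring. In a functional assay on HCT-15 cells (Homo sapiens) for inhibition, read by sulforhodamine B assay, with a stated time of 48 h (a lower number here means a stronger inhibitor of growth, a higher number a weaker inhibitor of growth), compound 1 gives 1230 nM. In this assay compound 2 gives 1230 nM. That single measured step reads no change at the digits printed from compound 1 to compound 2 (within the scatter), so compound 2 stands level with compound 1, neither stronger nor weaker.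

Compound 3 `O=C(Nc1cccc(-n2cc(-c3ccncc3)c(-c3ccc(Cl)c(O)c3)n2)c1)Nc1ccc(Cl)c(C(F)(F)F)c1` keeps all of compound 2 except at one place: trifluoromethyl in place of chloro on an aromatic carbon, a trifluoromethyl in place of chloro on an aromatic carbon, ortho to a chloro group and meta to a large group. Within the data shown here, no measured pair differs at this end of the molecule, and the one measured step, at the methoxy oxygen, offers no guide here. With nothing to lean on, the expectation for compound 3 is a result close to compound 2, an estimate in this assay of 1200 nM with a likely range from 400 nM to 3600 nM, meaning an expected step of a 1.0-fold lower number from compound 2 to compound 3 (0.01 log units; within the scatter), no larger than the scatter.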

Compound 3, concentration for 50% growth inhibition: 867 nM
Beside the measured number, compound 3's estimate is 1.4-fold (0.14 log units) above it; low and high end bracket the measured number.
By their numbers in this assay, from the lowest: compounds 3, 1 and 2 (each within the scatter of the next).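

Among these compounds, this is the first measured change at the urea aryl end of the molecule, and in this assay the swap of 3,4-dichlorophenyl for 4-chloro-3-(trifluoromethyl)phenyl gives a 1.4-fold lower number from compound 2 to compound 3 (0.15 log units; within the scatter) and so leaves the two compounds indistinguishable in this read-out. The place in question, an aromatic carbon ortho to a chloro group, therefore holds a trifluoromethyl group of 4 heavy atoms as well as a chloro group of 1 heavy atom, at least for this one pair and with the hydroxyl group kept on the other aryl ring. No measurement of any property of these groups accompanies the result, so the data offer no explanation of why the growth-inhibition number stays within the scatter.

The compounds shown leave open whether a different group at this same carbon, such as an amine, a carboxylic acid or a longer chain like propyl, would shift the number beyond the scatter. They also leave open whether trifluoromethyl would read the same way on compound 1, which carries the methoxy group instead of the hydroxyl group.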